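This account rests on a few compounds, and the source may have more. Where it says the series, first, only, none or still open, it means among the compounds named here.

Compound 1 `c1ccc2[se]cnc2c1`: > 40000 nM
Compound 2 `C=Cc1nc2ccccc2[se]1`: > 40000 nM

In a functional assay on HCT-116 cells (Homo sapiens) for cytotoxicity, with a stated time of 3 days (on this read-out lower numbers stand for stronger inhibition and higher numbers for weaker inhibition), compound 1 gives > 40000 nM, which is a limit of the assay and not a number. Compound 2 gives > 40000 nM in this assay, again only a limit. The step that the two limits leave unreadable from compound 1 to compound 2 is therefore unreadable, both values sitting at the limit of > 40000 nM in this assay, at which 2 of the 2 values shown sit. Compound 3 `C#Cc1nc2ccccc2[se]1` differs from compound 2 by ethynyl in place of vinyl on an aromatic carbon. Going by the values given here, the single measured step touches this change but gives no readable size or direction, so no step beyond the scatter can be foreseen in this assay from the data. Compound 3 is expected at 60000 nM, within 15000 nM to 200000 nM, most likely again a limit. This means an expected step that the limit leaves unreadable from compound 2 to compound 3.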

Compound 3, half-maximal inhibitory concentration: 25000 nM
Estimate against measurement, compound 3: 2.4-fold (0.38 log units) above; the measured number falls inside the stated range.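

Going by these compounds alone, with ethynyl on the aromatic carbon next to the ring nitrogen and the ring selenium, compound 3 gives 25000 nM in this assay, the first value here that is a number and not a limit. This yields a readable bound for two changes at this position: an at least 1.6-fold lower number from compound 2 to compound 3 (0.20 log units; that floor lies within the scatter) and an at least 1.6-fold lower number from compound 1 to compound 3 (0.20 log units; that floor lies within the scatter). The other values shown remain limits: the limit of > 40000 nM in this assay, at which 2 of the 3 values shown sit.

Going by these compounds, both floors lie within the scatter, so the true size of either step stays open. Also open, on these data alone, is how an amine or a longer chain at this position would compare with ethynyl.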